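Replacing diethylamino with ethoxy on an ethyl ester

The source may report more compounds than this note shows. Statements on the series, on what has been measured and on what is new or still open speak of the compounds shown alone.

In a functional assay on HCT-116 cells (Homo sapiens) for antiproliferative activity, with a stated time of 48 h (on this read-out lower numbers stand for stronger inhibition and higher numbers for weaker inhibition), compound 1 `CCN(CC)c1ccc(-c2ccc(C(=O)OC)cc2)nn1` gives 60 nM. Compound 2 `CCN(CC)c1ccc(-c2ccc(C(=O)O)cc2)nn1` is reported only as a limit of the assay, > 25000 nM. Compound 3 `CCOC(=O)c1ccc(-c2ccc(N(CC)CC)nn2)cc1` gives 500 nM, the higher of the two actual numbers, which is an 8.3-fold higher number from compound 1 to compound 3 (0.92 log units; beyond the scatter).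

Compound 4 `CCOC(=O)c1ccc(-c2ccc(OCC)nn2)cc1` differs from compound 3 by having ethoxy in place of diethylamino on an aromatic carbon, next to the ring nitrogen and para to a large group (ethoxy in place of diethylamino on an aromatic carbon). Among the compounds with values here, no measured step changes diethylamino, so the evidence is indirect. All three steps alter the ester end instead. Two are large, an at least 410-fold higher number from compound 1 to compound 2 (2.61 log units; beyond the scatter) and an at least 50-fold lower number from compound 2 to compound 3 (1.69 log units; beyond the scatter), and both rest on the limit. The smaller step, an 8.3-fold higher number from compound 1 to compound 3 (0.92 log units; beyond the scatter), is the more useful guide to size, and it suggests a modest rise in this assay rather than a collapse. The expected change is a 3.0-fold higher number from compound 3 to compound 4 (0.48 log units; beyond the scatter), though its direction is uncertain. For compound 4 the estimated value is 1500 nM, with an expected range from 150 nM to 15000 nM.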

Compound 4, half-maximal inhibitory concentration: > 25000 nM
Compound 4 was reported as a limit (the forecaster's own chance of this, stated with the estimate: 15%); middle value at least 16-fold (1.22 log units) from the limit.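

Until now every step had altered the ester end, so the diethylamino group had not been tested. In this assay, the step at the aromatic carbon next to the ring nitrogen, an at least 50-fold higher number from compound 3 to compound 4 (1.69 log units; beyond the scatter), shows that this position matters at least as much as the ester end: with the ethyl ester kept, ethoxy in place of diethylamino is enough to take the compound out of the measurable range. Compound 4 is reported only as a limit, so the size of this step is a lower bound and not a measured difference: the limit of > 25000 nM in this assay, at which 2 of the 4 values shown sit.

The compounds shown do not separate the change from nitrogen to oxygen from the loss of heavy atoms, which a dimethylamino group or a longer alkoxy chain such as butoxy on the same carbon could address. They also leave open whether a methyl ester, as in compound 1, would give a different result with ethoxy on this carbon.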